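Replacing the Furanylphenyl Group of Compound 3

The compounds below may be only part of what the source reports. "The series", "measured", "known", "first", "only" and "open" are said of these compounds alone.

Of the compounds shown here, three sharing one core have been tested in a functional assay on the whole organism with Mus musculus as the target, in the maximal electroshock model, with a stated time of 0.5 h; a lower number here means that less compound is needed, a higher number that more compound is needed for the effect. Compound 1 `CN(C)c1ccc(C2C=C(n3cc(-c4ccccc4)nc3-c3ccccc3)N=C(S)N2)cc1` gives 100 mg/kg, and compound 2 `SC1=NC(n2nc(-c3ccccc3)nc2-c2ccccc2)=CC(c2ccc(-c3ccccc3)cc2)N1` gives 100 mg/kg. Compound 3 `SC1=NC(n2nc(-c3ccccc3)nc2-c2ccccc2)=CC(c2ccc(-c3ccco3)cc2)N1` gives 30 mg/kg, the lowest of the three numbers, and its steps to compound 1 and to compound 2 are both beyond the scatter. Going by the values given here, the single measured step, a 3.3-fold lower number from compound 2 to compound 3 (0.52 log units; beyond the scatter), arose from furan-2-yl in place of phenyl on an aromatic carbon.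

Compound 4 `COc1ccc(C2C=C(n3nc(-c4ccccc4)nc3-c3ccccc3)N=C(S)N2)c(OC)c1` has not yet been measured. It differs from compound 3 as follows: 2,4-dimethoxyphenyl in place of 4-(furan-2-yl)phenyl on a saturated ring carbon. Among the compounds with values here, no measured step involves a 2,4-dimethoxyphenyl group, so none bears directly on this change. Compound 4 is nevertheless expected to give a higher number because a 3.3-fold lower number from compound 2 to compound 3 (0.52 log units; beyond the scatter) went with the very furan-2-yl group that compound 4 gives up. A step of a 3.3-fold higher number from compound 3 to compound 4 (0.52 log units; beyond the scatter) is therefore expected. The estimate for compound 4 in this assay is 100 mg/kg, with a range from 30 mg/kg to 300 mg/kg.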

Compound 4, minimum effective dose: 30 mg/kg
For compound 4 the middle estimate is 3.3-fold (0.52 log units) above the measured one; low and high end bracket the measured number.
By their numbers in this assay, from the lowest: compounds 3 and 4 (each within the scatter of the next); then compounds 1 and 2 (each within the scatter of the next).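

In this assay, putting 2,4-dimethoxyphenyl on the saturated ring carbon in place of 4-(furan-2-yl)phenyl gives no change at the digits printed from compound 3 to compound 4 (within the scatter), so the lower number at this position does not depend on a furan-2-yl group. The same group in place of 4-phenylphenyl gives a 3.3-fold lower number from compound 2 to compound 4 (0.52 log units; beyond the scatter), which shows that a single aromatic ring of carbon only, carrying two methoxy groups, can match the two-ring 4-(furan-2-yl)phenyl group, whereas the two-ring 4-phenylphenyl group of compound 2 does not.

The compounds shown leave open whether both methoxy groups are needed, since neither is ever present alone. They also leave open how an amine, a carboxylic acid or a longer alkyl chain on that phenyl ring would compare. Nothing at hand offers a measured explanation for this result.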